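Replacing the Oxetane Ring with a Pyridine Ring

This account rests on a few compounds, and the source may have more. Where it says the series, first, only, none or still open, it means among the compounds named here.

Compound 1 `CN(C[C@H]1Cc2c(cccc2N2CCN(C3COC3)CC2)CN1)[C@H]1CCCc2cccnc21` in an ADME assay on microsomes from liver (Mus musculus) for metabolic stability, read by LC-MS, with a stated time of 10 min (a lower number here means that less of the compound is left, a higher number that more of the compound is left), gives 50.8%, the second highest of the three measured numbers. Compound 2 `CN(C[C@H]1Cc2c(cccc2N2CCN3CCC[C@H]3C2)CN1)[C@H]1CCCc2cccnc21` gives 40.1% and compound 3 `CN(C[C@H]1Cc2c(cccc2N2C[C@H]3C[C@@H]2CN3)CN1)[C@H]1CCCc2cccnc21` gives 95.9%. The measured steps, a number 10.7 percentage points lower from compound 1 to compound 2 (beyond the scatter) and a number 45.1 percentage points higher from compound 1 to compound 3 (beyond the scatter), both exchange the whole group on the aromatic carbon, so they show that this part of the shared core can move the readout a great deal, but neither swaps one small group for another on the ring nitrogen. Compound 4 `CN(C[C@H]1Cc2c(cccc2N2CCN(c3ccccn3)CC2)CN1)[C@H]1CCCc2cccnc21` makes such a swap: pyridin-2-yl in place of oxetan-3-yl on an amine nitrogen in a ring. Among the compounds with values here, with no directly comparable step, a modest change is expected, estimated as a number 8.8 percentage points lower from compound 1 to compound 4 (within the scatter), giving compound 4 an expected 42% with a range from 20% to 66%.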

Compound 4, percent of the compound remaining: 46.1%
Beside the measured number, compound 4's estimate is 4.1 percentage points below it; the measured number falls inside the stated range.
By their numbers in this assay, from the lowest: compounds 2, 4 and 1 (each within the scatter of the next, the first and the last beyond it); then compound 3.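

In this assay the swap on the amine nitrogen in a ring gives a number 4.7 percentage points lower from compound 1 to compound 4 (within the scatter) and so leaves the number within the usual scatter, unlike the two exchanges of the whole group on the aromatic carbon. At this nitrogen, then, a six-membered aromatic ring and a four-membered non-aromatic ring give readouts that cannot be told apart. No measured evidence explains this result. Still open, going by these compounds, is whether a plain phenyl ring, a methyl group or an acetyl group on this nitrogen would also stay within the scatter.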